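Spiro scaffold with cyclohexylbenzoyl group: amide to ester

This account rests on a few compounds, and the source may have more. Where it says the series, first, only, none or still open, it means among the compounds named here.

Measured compounds:
- compound 1, `CCc1nn(CC)c(C2CCN(C(=O)CN3CN(c4ccccc4)C4(CCN(C(=O)c5ccc(C6CCCCC6)cc5)CC4)C3=O)CC2)c1C`, in an assay on HEK293 cells for displacement of a labelled ligand from NPC1-like intracellular cholesterol transporter 1 (Homo sapiens) (on this read-out higher numbers stand for weaker inhibition and lower numbers for stronger inhibition), compound 1 gives "not determined" (no result reported)
- compound 2, `O=C(CN1CN(c2ccccc2)C2(CCN(C(=O)c3ccc(C4CCCCC4)cc3)CC2)C1=O)N1CCC(CO)CC1`, 1100 nM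
- compound 3, `CC(C)(C)c1ccc(C(=O)N2CCC3(CC2)C(=O)N(CC(=O)N2CCN(S(C)(=O)=O)CC2)CN3c2ccccc2)cc1`, 19000 nM

Three compounds share the same spiro core with a phenyl group on one nitrogen and an acyl group on the piperidine nitrogen. Compound 1 carries a pyrazolylpiperidine amide, and in this assay compound 1 gives "not determined" (no result reported), so it has no number. Compound 2, with the cyclohexylbenzoyl group and the 4-(hydroxymethyl)piperidin-1-yl amide, gives in this assay a value of 1100 nM, the lowest of the two numbers shown. Among the compounds with values here, compound 3, with a tert-butylbenzoyl group and a methanesulfonylpiperazinyl amide, gives in this assay 19000 nM, a much higher number than compound 2, beyond the scatter; since compound 3 differs from compound 2 in two places, no single step between them is counted.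

Compound 4, `CC1(C)CC(OC(=O)CN2CN(c3ccccc3)C3(CCN(C(=O)c4ccc(C5CCCCC5)cc4)CC3)C2=O)CC(C)(C)N1`, differs from compound 2 in one place: (2,2,6,6-tetramethylpiperidin-4-yl)oxy in place of 4-(hydroxymethyl)piperidin-1-yl on a carbonyl carbon. The amide of compound 2 becomes an ester in compound 4. Within the data shown here, no measured pair shows what such a change does here, so the expected step of a 1.4-fold higher number from compound 2 to compound 4 (0.13 log units; within the scatter) is small, in either direction or none beyond the scatter. For compound 4 the estimated value in this assay is 1500 nM, within a range of 500 nM to 5000 nM.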

Compound 4, half-maximal inhibitory concentration: 600 nM
Compound 4: the middle estimate sits 2.5-fold (0.40 log units) above what was measured; low and high end bracket the measured number.
By their numbers in this assay, from the lowest: compounds 4 and 2 (each within the scatter of the next); then compound 3.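

In this assay, within the data shown here, the first step with a single difference at this carbonyl carbon reads a 1.8-fold lower number from compound 2 to compound 4 (0.26 log units; within the scatter) and lies within the usual scatter. This carbonyl carbon can therefore carry an ester in place of an amide, and a (2,2,6,6-tetramethylpiperidin-4-yl)oxy group of 11 heavy atoms in place of a 4-(hydroxymethyl)piperidin-1-yl group of 8, with no difference that this read-out can separate. Both groups hold one six-membered non-aromatic ring with 1 hetero atom and 1 hydrogen-bond donor, so the pair covers two quite different ways of attaching such a ring to the carbonyl carbon.

This one step joins the ester link and the new ring, and the compounds shown do not separate the two; a (2,2,6,6-tetramethylpiperidin-4-yl)amino group on the same carbonyl carbon would do so. They also leave open how far the position reaches, for instance with a carboxylic acid or a plain ethoxy group there, or with a methyl group on the nitrogen of the tetramethylpiperidine ring. No measurement at hand speaks to the reason for this result.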